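A few compounds are considered here, and "the series" means these few. Any claim that something is new, unique, unknown or untested is made for them only; others in the source may bear on it.

Measured so far in a functional assay on the whole organism (blood) with Rattus norvegicus as the target, with stated times of 24 h and 1 h, at a dose of 5 mg/kg by the intraperitoneal route; a higher number here means a stronger effect of the compound at the dose given, a lower number a weaker effect:

Compound 1, `O=C(NC1CCCCC1)NS(=O)(=O)N1CCC(CCNC(=O)C(F)(F)F)CC1`, gives 13%.
Compound 2, `O=C(NC[C@@H]1C[C@@H]2C=C[C@@H]1C2)NS(=O)(=O)N1CCC(CCNC(=O)C(F)(F)F)CC1`, gives 22%.
Compound 3, `Cc1ncccc1C(=O)NCCC1CCN(S(=O)(=O)NC(=O)NC2CCCCC2)CC1`, gives 16%.

Compound 1 and compound 2 differ in one place: a group of 8 heavy atoms (8 carbon; 2 five-membered non-aromatic rings of carbon only) in place of a group of 6 heavy atoms (6 carbon; one six-membered non-aromatic ring of carbon only), on an amide-type nitrogen. This change made a number 9 percentage points higher from compound 1 to compound 2 (within the scatter). Compound 3 is built on a different core from compound 1; the two cores differ by 2-methylpyridin-3-yl in place of trifluoromethyl on a carbonyl carbon, and that difference made a number 3 percentage points higher from compound 1 to compound 3 (within the scatter).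

Compound 4, `Cc1ncccc1C(=O)NCCC1CCN(S(=O)(=O)NC(=O)NC[C@@H]2C[C@@H]3C=C[C@@H]2C3)CC1`, has not yet been measured in this assay. It stands to compound 3 as compound 2 stands to compound 1: a group of 8 heavy atoms (8 carbon; 2 five-membered non-aromatic rings of carbon only) in place of a group of 6 heavy atoms (6 carbon; one six-membered non-aromatic ring of carbon only), on an amide-type nitrogen. The place of the change reads the same in both pairs, so this is the same change, now made on the core of compound 3.

Because the same change once gave a number 9 percentage points higher from compound 1 to compound 2 (within the scatter), the step from compound 3 to compound 4 in this assay is expected to be a number 9 percentage points higher from compound 3 to compound 4 (within the scatter), about the size of the earlier one. This expectation rests on one pair only, compound 1 and compound 2. On that basis compound 4 is estimated to give 25%, with a likely range from 10% to 40%.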

Compound 4, a percentage reported as activity, at one dose (the size of the read-out at that dose, not a potency): 16%
Estimate against measurement, compound 4: 9 percentage points above, and the stated range covers the measured number.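

In this assay, the group of 8 heavy atoms in place of cyclohexyl on the core of compound 3 gave no change at the digits printed from compound 3 to compound 4 (within the scatter), and this matches the step seen earlier on the other core as closely as the scatter lets one tell: the same change on two cores in this assay, a number 9 percentage points higher (within the scatter) from compound 1 to compound 2 and no change at the digits printed (within the scatter) from compound 3 to compound 4, 9 percentage points apart, within the scatter of two such steps. Likewise, 2-methylpyridin-3-yl in place of trifluoromethyl gave a number 6 percentage points lower from compound 2 to compound 4 (within the scatter), which also sits close to its earlier counterpart: the same change on two cores in this assay, a number 3 percentage points higher (within the scatter) from compound 1 to compound 3 and a number 6 percentage points lower (within the scatter) from compound 2 to compound 4, 9 percentage points apart, within the scatter of two such steps. So nothing here shows that either change behaves differently on the two cores, but with every step inside the scatter, nothing shows that either change has a real effect that carries over from one core to the other.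

The compounds shown leave open whether another group on the carbonyl carbon, such as a phenyl ring, a longer alkyl chain or one bearing an amine or a carboxylic acid, would move the read-out of this assay beyond the scatter. They also leave open whether these changes would separate at other doses.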